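The source may hold more compounds than are shown below. What is called first, only, known or untested is meant among the compounds shown, and "the series" means these compounds.

Working notes on the series. All measurements so far come from a functional assay on Jurkat cells (Homo sapiens) for antiproliferative activity, read by WST assay, with a stated time of 72 h; on this read-out lower numbers stand for stronger inhibition and higher numbers for weaker inhibition. Compound 1 `Clc1ccc2[nH]c(-c3nc(-c4ccccc4)no3)cc2c1` gives only a limit in this assay, > 50000 nM, and no number. Compound 2 `O=[N+]([O-])c1ccc2[nH]c(-c3nc(-c4ccc(Cl)cc4)no3)cc2c1` likewise gives only the limit > 50000 nM in this assay. Where compound 2 stands is therefore fixed from one side only: the single anchor in the data is the limit of > 50000 nM in this assay, at which 2 of the 2 values shown sit, so there is no ranked position and no measured step between the two compounds to draw on; what the pair shows is merely that neither reached a measurable half-maximal inhibitory concentration.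

Compound 3 `Clc1ccc(-c2noc(-c3cc4cc(Cl)ccc4[nH]3)n2)cc1` differs from compound 2 by chloro in place of nitro on an aromatic carbon. Going by the values given here, with both known values at the limit, a change of this kind has no measured counterpart here, and the size of any step can only be judged by expectation. The expectation is that the change carries no shift beyond the scatter and that the estimated step that the limit leaves unreadable from compound 2 to compound 3 stays small. Compound 3 is expected to give about 60000 nM in this assay, within 15000 nM to 250000 nM, with a high chance that the assay again reports only a limit.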

Compound 3, half-maximal inhibitory concentration: > 50000 nM
Compound 3: a limit, no number; the forecaster's own chance of this, stated with the estimate: 80%; the middle value is on the limit's open side.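

In this assay compound 3 gives only a limit, > 50000 nM. No step can be read from compound 2 to compound 3 or from compound 1 to compound 3, and the only anchor remains the limit: the limit of > 50000 nM in this assay, at which 3 of the 3 values shown sit.

The compounds shown leave open whether any change on the shared core gives a measurable half-maximal inhibitory concentration.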